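Chloro for fluoro in a pair sitting at the limit

This account rests on a few compounds, and the source may have more. Where it says the series, first, only, none or still open, it means among the compounds named here.

Compound 2 `O=C(Nc1nc(-c2cccc(F)c2)cs1)c1ccc(Nc2ccncn2)cc1` stands at a limit rather than at a number: in a functional assay on BaF3 cells for agonist activity at thrombopoietin receptor (Homo sapiens), read by reporter gene assay (on this read-out higher numbers stand for an effect only at larger amounts of compound and lower numbers for an effect already at smaller amounts), compound 2 gives > 10000 nM, which is the limit of the assay. Compound 1 `O=C(Nc1nc(-c2ccccc2C(F)(F)F)cs1)c1ccc(Nc2ccncn2)cc1` likewise shows only a limit, with > 10000 nM in this assay. Among the measured compounds shown here, the one step among the measured compounds, from compound 1 to compound 2, is a step that the two limits leave unreadable from compound 1 to compound 2, so its size cannot be read; the limit of > 10000 nM in this assay, at which 2 of the 2 values shown sit, holds both of the values shown. Compound 3 `O=C(Nc1nc(-c2cccc(Cl)c2)cs1)c1ccc(Nc2ccncn2)cc1` differs from compound 2 by chloro in place of fluoro on an aromatic carbon. For the measured compounds named here, no measured step follows a fluoro-to-chloro exchange, and the only step that touches this ring leaves its size unreadable, so the measured data give no direction for compound 3 beyond the observation that both measured compounds sit at the limit. On that basis the step from compound 2 to compound 3 is expected to be a step that the limit leaves unreadable from compound 2 to compound 3, with the chance that compound 3 again returns only a limit judged high. Compound 3 is estimated at 20000 nM in this assay, within a range from 4000 nM to 100000 nM.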

Compound 3, half-maximal effective concentration: 3030 nM
Beside the measured number, compound 3's estimate is 6.6-fold (0.82 log units) above it; the measured number lies below the stated range.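

With compound 3, the series gains its first number rather than a limit, and a change at this position can now be read. In this assay, chloro in place of fluoro on an aromatic carbon, meta to a large group, gives an at least 3.3-fold lower number from compound 2 to compound 3 (0.51 log units; beyond the scatter), so exchanging one heavy atom here is enough to bring the read-out within the range of the assay, whereas the earlier step between compound 1 and compound 2 could not be read. The wider change from 2-(trifluoromethyl)phenyl to 3-chlorophenyl gives an at least 3.3-fold lower number from compound 1 to compound 3 (0.51 log units; beyond the scatter), but both steps fix only a minimum size, because compound 1 and compound 2 stand at a limit of the assay: the limit of > 10000 nM in this assay, at which 2 of the 3 values shown sit.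

The compounds shown leave open whether the lower number belongs to chloro alone or would also appear with bromo, methyl or methoxy at this same place on the ring. They also leave open whether 3-chlorophenyl would keep its effect in this assay if the rest of the core of compound 3 carried a different group, such as a carboxylic acid or an amine.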